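A few compounds are considered here, and "the series" means these few. Any claim that something is new, unique, unknown or untested is made for them only; others in the source may bear on it.

Measured compounds in a functional assay on CRL2813 cells (Homo sapiens) for cytotoxicity, read by sulforhodamine B assay, with a stated time of 5 days; a higher number here means a weaker inhibitor, a lower number a stronger inhibitor:
compound 1, `O=C(Nc1cccc(C(=O)O)c1)N[C@H]1CC[C@H](Oc2ccc(F)cc2)CC1`, gives > 20000 nM, a limit of the assay.
compound 2, `COc1ccc(NC(=O)N[C@H]2CC[C@H](Oc3ccc(F)cc3)CC2)cc1`, gives > 20000 nM, a limit of the assay.
compound 3, `O=C(Nc1ccc(Cl)cc1)N[C@H]1CC[C@H](Oc2ccc(F)cc2)CC1`, gives > 20000 nM, a limit of the assay.

Compound 3 therefore stands at the limit, and the two further values shown are limits as well (the limit of > 20000 nM in this assay, at which 3 of the 3 values shown sit). Going by the values given here, none of the measured steps can be read as a number: the step that the two limits leave unreadable from compound 1 to compound 3 is unreadable, as are a step that the two limits leave unreadable from compound 1 to compound 2 and a step that the two limits leave unreadable from compound 2 to compound 3, because both ends of each sit at the limit (the limit of > 20000 nM in this assay, at which 3 of the 3 values shown sit).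

The next compound, compound 4, `O=C(Nc1ccccc1)N[C@H]1CC[C@H](Oc2ccc(F)cc2)CC1`, differs from compound 3 by hydrogen in place of chloro on an aromatic carbon, on an aromatic carbon of a six-membered aromatic ring of carbon only; cut one bond further out, the change reads 4-chlorophenyl to phenyl.

Among the compounds with values here, the steps that bear on it, 4-methoxyphenyl in place of 3-carboxyphenyl and chloro in place of methoxy on the same aryl group, left no readable size, so no direction can be drawn from them for this assay. Given that compound 3 gives > 20000 nM, compound 4 is expected to remain at or near the limit, with the step that the limit leaves unreadable from compound 3 to compound 4 estimated as no more than the scatter. The estimate for compound 4 is 25000 nM, within 8000 nM to 80000 nM.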

Compound 4, half-maximal inhibitory concentration: 20000 nM
Estimate against measurement, compound 4: 1.3-fold (0.10 log units) above; the range from low to high includes it.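

In this assay, going by these compounds alone, compound 4 gives 20000 nM, the first number rather than a limit, which places the plain phenyl group at the very edge of the range the assay reports. Compound 3 gives > 20000 nM, which is a limit. Hydrogen in place of chloro therefore gives a number no higher from compound 3 to compound 4 (the limit leaves the size open). Hydrogen in place of methoxy gives a number no higher from compound 2 to compound 4 (the limit leaves the size open), and hydrogen in place of carboxy gives a number no higher from compound 1 to compound 4 (the limit leaves the size open). No gain from removing the substituent can be claimed, with the series still sitting at the edge of the range: the limit of > 20000 nM in this assay, at which 3 of the 4 values shown sit.

From the compounds shown here alone, whether any group at this position on the aromatic ring can bring a value clearly under the limit stays open, for instance an amine, a hydroxyl or a longer alkyl chain in place of the hydrogen of compound 4. The shared core and its fluorophenyl ether are the same in all the compounds shown, so what a change there would do in this assay also stays open.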